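A few compounds are considered here, and "the series" means these few. Any claim that something is new, unique, unknown or untested is made for them only; others in the source may bear on it.

Compound 1 `CCc1cc(C(=O)N2CC=CC2)cc(C#N)c1O` gives 54% in an assay on isolated protein for inhibition of solute carrier family 22 member 12 (Homo sapiens), tested at 3 uM; a higher number here means more inhibition at the concentration tested (going by the name of the read-out), a lower number less inhibition.
Compound 2 `Cc1cc(C(=O)N2CC=CC2)cc(C#N)c1O` gives 25% in this assay.

For the measured compounds named here, compound 2 stands lowest of the two measured numbers; its only neighbour is compound 1, whose number lies well above it, beyond the scatter. Going by the values given here, the single measured step that bears on the new compound is the one between these two, where the chain on the aromatic carbon was shortened from ethyl to methyl: a number 29 percentage points lower from compound 1 to compound 2 (beyond the scatter). Compound 3 `CCCc1cc(C(=O)N2CC=CC2)cc(C#N)c1O` moves in the opposite sense and further, from methyl to propyl: ethyl in place of hydrogen on a saturated chain carbon bound to an aromatic carbon. On that basis, lengthening the chain is expected to raise inhibition in this assay, roughly by the amount the shortening lost, although no chain longer than ethyl has been measured, so the size is uncertain. The expected step is a number 30 percentage points higher from compound 2 to compound 3 (beyond the scatter). Compound 3 is therefore estimated at 55%, within a range from 35% to 75%.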

Compound 3, a percentage reported as inhibition, at one concentration (the size of the read-out at that concentration, not a potency): 70%
Estimate against measurement, compound 3: 15 percentage points below; low and high end bracket the measured number.
By their numbers in this assay, from the lowest: compound 2; then compound 1; then compound 3.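

In this assay, lengthening the chain on the aromatic carbon from ethyl to propyl gives a number 16 percentage points higher from compound 1 to compound 3 (beyond the scatter), so the gain does not stop at ethyl. Read from the shortest chain, the whole change of ethyl in place of hydrogen on a saturated chain carbon bound to an aromatic carbon gives a number 45 percentage points higher from compound 2 to compound 3 (beyond the scatter), and across methyl, ethyl and propyl the number rises with each lengthening, with no compound here going against that trend. Nothing available here explains this rise.

Three chain lengths cannot show where the rise ends, so a butyl or pentyl chain might continue it, level off or reverse it. Going by these compounds, it also remains open whether a branched isopropyl group or a cyclopropyl ring at this place would match the straight propyl chain.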